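This account rests on a few compounds, and the source may have more. Where it says the series, first, only, none or still open, it means among the compounds named here.

Measured compounds in a functional assay on PC-3 cells (Homo sapiens) for cytotoxicity, read by MTT assay, with a stated time of 48 h; on this read-out lower numbers stand for stronger inhibition and higher numbers for weaker inhibition:

Compound 1, `COc1cc(-c2nnc3n2NC(c2ccco2)C(C(=O)c2ccccc2C)S3)cc(OC)c1OC`, gives 88400 nM.
Compound 2, `COc1cc(-c2nnc3n2NC(c2ccco2)C(C(=O)C2CC2)S3)cc(OC)c1OC`, gives 95200 nM.
Compound 3, `COc1ccc(C(=O)C2Sc3nnc(-c4cc(OC)c(OC)c(OC)c4)n3NC2c2ccco2)cc1`, gives only a limit, > 100000 nM.

Compound 3 thus stands at the limit of > 100000 nM in this assay, at which 1 of the 3 values shown sits, with no number of its own. Its steps from the two measured neighbours, an at least 1.1-fold higher number from compound 1 to compound 3 (0.05 log units; that floor lies within the scatter) and an at least 1.0-fold higher number from compound 2 to compound 3 (0.02 log units; that floor lies within the scatter), are floors that lie within the scatter, as does a 1.1-fold higher number from compound 1 to compound 2 (0.03 log units; within the scatter). All three measured compounds differ only in the group on the carbonyl carbon, and none of those changes moved the read-out beyond the scatter.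

Compound 4, `COc1cc(-c2nnc3n2NC(c2ccco2)C(C(=O)c2ccc([N+](=O)[O-])cc2)S3)cc(OC)c1OC`, differs from compound 3 by nitro in place of methoxy on an aromatic carbon. The change again sits on the carbonyl substituent, the only position that has been varied so far. Every measured step at this position was within the scatter, so no step beyond the scatter is expected in this assay in either direction. Compound 4 is expected at 100000 nM, between 55000 nM and 200000 nM. The expected step is a number no higher from compound 3 to compound 4 (the limit leaves the size open), within the scatter, with a fair chance that only a limit is again reported.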

Compound 4, half-maximal inhibitory concentration: 27900 nM
Compound 4: the middle estimate sits 3.6-fold (0.55 log units) above what was measured; measured number outside the range, below it.
By their numbers in this assay, from the lowest: compound 4; then compounds 1 and 2 (each within the scatter of the next). At a limit, above all of these: compound 3.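

In this assay, the group on the carbonyl carbon can change the read-out: 4-nitrophenyl is the only group shown that moves it beyond the scatter, with a 3.4-fold lower number from compound 2 to compound 4 (0.53 log units; beyond the scatter) and a 3.2-fold lower number from compound 1 to compound 4 (0.50 log units; beyond the scatter). Nitro in place of methoxy on the aromatic ring gives an at least 3.5-fold lower number from compound 3 to compound 4 (0.55 log units; beyond the scatter). Compound 3 has only a limit, which makes that step a floor and leaves its full size unknown: the limit of > 100000 nM in this assay, at which 1 of the 4 values shown sits.

The compounds shown leave open whether this shift is particular to nitro or would also appear with a nitrile, a carboxylic acid or an amine at the same place on the ring. The shift beyond the scatter also rests on compound 4 alone, and no second compound shown carries nitro.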